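Para-substituent on the pyrazole aryl ring: from chloro through hydrogen to nitro

The compounds below may be only part of what the source reports. "The series", "measured", "known", "first", "only" and "open" are said of these compounds alone.

Values in a functional assay on HCT-116 cells (Homo sapiens) for inhibition, read by MTT assay, with a stated time of 48 h; on this read-out higher numbers stand for weaker inhibition and lower numbers for stronger inhibition:
compound 1 `COc1cc2ccc(=O)oc2cc1OC(=O)c1c(-c2ccc(Cl)cc2)n[nH]c1C`: 13800 nM
compound 2 `COc1cc2ccc(=O)oc2cc1OC(=O)c1c(-c2ccccc2)n[nH]c1C`: > 25000 nM

In this assay compound 2 gives > 25000 nM, which is a limit of the assay and not a number. Compound 1 gives 13800 nM. For the measured compounds named here, the only measured step, an at least 1.8-fold higher number from compound 1 to compound 2 (0.25 log units; that floor lies within the scatter), runs from compound 1 into that limit (the limit of > 25000 nM in this assay, at which 1 of the 2 values shown sits), so the true gap between the two is not known. Compound 3 `COc1cc2ccc(=O)oc2cc1OC(=O)c1c(-c2ccc([N+](=O)[O-])cc2)n[nH]c1C` is not yet measured. It differs from compound 2 by nitro in place of hydrogen on an aromatic carbon.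

Going by the values given here, no measured step concerns a nitro group; the one step on record, an at least 1.8-fold higher number from compound 1 to compound 2 (0.25 log units; that floor lies within the scatter), concerns the loss of a chloro and says nothing about what an entering nitro does at the same place. Both measured values are weak and one is a limit, so compound 3 is expected to stay in the same weak region, with no direction that can be justified beyond the scatter. The expected step is an at least 1.1-fold lower number from compound 2 to compound 3 (0.05 log units; that floor lies within the scatter). For compound 3 the estimate in this assay is 22000 nM, with a range of 8000 nM to 60000 nM, and a considerable chance that the assay again reports only a limit.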

Compound 3, half-maximal inhibitory concentration: > 25000 nM
Compound 3 gave a limit, no number (the forecaster's own chance of this, stated with the estimate: 50%); middle value at least 1.1-fold (0.05 log units) away from the limit.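

In this assay compound 3 gives > 25000 nM as a limit of the assay and not a number. The change from phenyl to 4-nitrophenyl therefore cannot be read, and neither hydrogen nor nitro at this place gives a value that can be compared: the limit of > 25000 nM in this assay, at which 2 of the 3 values shown sit.

Nitro in place of chloro gives an at least 1.8-fold higher number from compound 1 to compound 3 (0.25 log units; that floor lies within the scatter) and leaves compound 1 as the only one of the three with a number, while the floor of that step gives no readable separation between chloro and nitro.

As far as these compounds go, how far compound 2 and compound 3 truly lie from compound 1 remains open, and so does whether the chloro of compound 1 marks any real preference at this place. An amine, a methoxy group or a bromine at the same place on the aryl ring could show whether other groups also give a number in this assay and whether any of them separates from compound 1 beyond the scatter.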